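Furan to methylthiophene on the amide side chain

This account rests on a few compounds, and the source may have more. Where it says the series, first, only, none or still open, it means among the compounds named here.

Compound 1 `CCN(Cc1ccco1)C(=O)COc1ccc(C)cc1`: 489 nM
Compound 2 `CCN(Cc1cccs1)C(=O)C(C)Oc1ccc(C)cc1`: 889 nM
Compound 3 `CCC(C)N(Cc1cccs1)C(=O)COc1ccc(C)cc1`: 2000 nM

In an assay on HEK293 cells for agonist activity at transient receptor potential cation channel subfamily M member 8 (Homo sapiens), read by fluorescence and calcium flux, with a stated time of 15 min (a higher number here means that more compound is needed for the effect, a lower number that less compound is needed), compound 1 gives 489 nM, the lowest of the three numbers. Compound 2 gives 889 nM, which lies within the scatter of compound 1, so no order can be read between them. Compound 3 gives 2000 nM, a gap from compound 1 that lies beyond the scatter; compound 3 differs from compound 1 in more than one place, so this gap cannot be assigned to a single change.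

Compound 4 `CCN(Cc1ccc(C)s1)C(=O)COc1ccc(C)cc1` differs from compound 1 in one place: 5-methylthiophen-2-yl in place of furan-2-yl on a saturated chain carbon bound to an amide-type nitrogen. Within the data shown here, no measured pair isolates this change, and compound 2 and compound 3 each carry further differences, so they offer no clean guide. In this assay the step from compound 1 to compound 4 is expected to be small, a 1.4-fold higher number from compound 1 to compound 4 (0.16 log units; within the scatter), a slight rise that may not exceed the scatter. Compound 4 is therefore estimated at 700 nM, with a range from 250 nM to 2000 nM.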

Compound 4, half-maximal effective concentration: 178 nM
For compound 4 the middle estimate is 3.9-fold (0.59 log units) above the measured one; the whole stated range lies above it.
By their numbers in this assay, from the lowest: compound 4; then compounds 1 and 2 (each within the scatter of the next); then compound 3.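

Among these compounds, compound 1 and compound 4 form the first pair here that differs in one place, and they isolate the group on a saturated chain carbon bound to an amide-type nitrogen. In this assay, 5-methylthiophen-2-yl in place of furan-2-yl gives a 2.7-fold lower number from compound 1 to compound 4 (0.44 log units; beyond the scatter), which shows that the number responds to this change even though the rest of the molecule stays the same. Nothing measured here explains the step.

The change swaps the ring oxygen for sulfur and also adds a methyl group, so the compounds shown leave open how much of the step belongs to each; a 5-methylfuran-2-yl group at this place would separate the two. Also open, as far as these compounds go, is how the number responds to other groups on the thiophene ring, such as 5-chlorothiophen-2-yl or 5-ethylthiophen-2-yl.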